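The compounds below may be only part of what the source reports. "The series", "measured", "known", "first", "only" and "open" are said of these compounds alone.

In a functional assay on RS4-11 cells (Homo sapiens) for inhibition, read by CCK-8 assay, with a stated time of 48 h (a lower number here means a stronger inhibitor, a higher number a weaker inhibitor), three compounds have been measured and none has returned a number. Compound 1 `COc1cccc(NC(=O)NCCNS(=O)(=O)c2ccc(-c3ccccc3OCc3ccccc3)s2)c1` reads > 20000 nM, which is a limit of the assay. Compound 2 `O=S(=O)(NCCNC(=S)Nc1cc(C(F)(F)F)cc(C(F)(F)F)c1)c1ccc(-c2ccccc2OCc2ccccc2)s1` reads > 50000 nM, which is also a limit. Compound 3 `COc1ccc(Oc2ccccc2-c2ccsc2S(=O)(=O)N2CCN(C(=O)Nc3cc(C(F)(F)F)cc(C(F)(F)F)c3)CC2)cc1OC` reads > 50000 nM, again a limit. Compound 1 stands alone at the limit of > 20000 nM in this assay, at which 1 of the 3 values shown sits. Compounds 2 and 3 share (the limit of > 50000 nM in this assay, at which 2 of the 3 values shown sit). These limits do not allow the three compounds to be ranked against one another.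

Compound 4 `O=S(=O)(NCCNC(=S)Nc1ccc(Cl)cc1)c1ccc(-c2ccccc2OCc2ccccc2)s1` retains the core of compound 1 and differs from it in one place: a group of 10 heavy atoms (7 carbon, 1 nitrogen, 1 sulfur, 1 chlorine; one six-membered aromatic ring of carbon only) in place of a group of 11 heavy atoms (8 carbon, 1 nitrogen, 2 oxygen; one six-membered aromatic ring of carbon only), on an amine nitrogen. The (3-methoxyphenyl)carbamoyl group leaves, and a group with no common name, containing sulfur and chlorine, enters on the same amine nitrogen. Within the data shown here, no measured step shows what a change of this kind does in this assay, so the expectation rests on the lack of any measured number so far. On that basis, compound 4 is expected to remain weak, with no clear direction of change. The estimated change is a number no higher from compound 1 to compound 4 (the limit leaves the size open), and no step beyond the scatter is expected. For compound 4, the estimated value is 20000 nM, with an expected range of 4000 nM to 60000 nM.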

Compound 4, half-maximal inhibitory concentration: > 50000 nM
Compound 4: a limit, no number; the forecaster's own chance of this, stated with the estimate: 65%; middle value at least 2.5-fold (0.39 log units) from the limit.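

In this assay compound 4 gives > 50000 nM, which is a limit of the assay and not a number. Compound 1 also stands at a limit, so the step between compound 1 and compound 4 cannot be read. The compounds shown leave open what measured value any of them would give, and whether changing the group on the amine nitrogen changes inhibition at all.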